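A few compounds are considered here, and "the series" means these few. Any claim that something is new, unique, unknown or untested is made for them only; others in the source may bear on it.

Compound 1 `O=C(NCc1ccc(NC(=O)c2cc(-c3ccccc3)ccc2N2CCCC2)cc1)OCc1cccnc1`: 10500 nM
Compound 2 `O=C(NCc1ccc(NC(=O)c2cccc(F)c2N2CCCC2)cc1)OCc1cccnc1`: > 100000 nM (a limit)

For the measured compounds named here, in a functional assay on MGC-803 cells (Homo sapiens) for inhibition, read by MTT assay, with a stated time of 72 h (on this read-out lower numbers stand for stronger inhibition and higher numbers for weaker inhibition), compound 1 gives 10500 nM, the only actual number so far. Compound 2 reaches only > 100000 nM, which is a limit of the assay and not a number. Compound 3 `O=C(NCc1ccc(NC(=O)c2cc(Br)ccc2N2CCCC2)cc1)OCc1cccnc1` has not yet been measured. It puts bromo in place of phenyl on an aromatic carbon, para to a pyrrolidin-1-yl group: bromo in place of phenyl on an aromatic carbon. Going by the values given here, no measured step covers this change, so the expectation rests on compound 1 at 10500 nM and on the size of the group that leaves. A moderate loss of inhibition in this assay is expected, though with wide uncertainty, and a result within the scatter would be no surprise. The estimated step is a 1.9-fold higher number from compound 1 to compound 3 (0.28 log units; within the scatter). For compound 3 the expected value is 20000 nM, with an estimated range of 3000 nM to 100000 nM.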

Compound 3, half-maximal inhibitory concentration: 45700 nM
For compound 3 the middle estimate is 2.3-fold (0.36 log units) below the measured one; the measured number falls inside the stated range.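

Replacing phenyl with bromo on this aromatic carbon, para to a pyrrolidin-1-yl group, gives in this assay a 4.4-fold higher number from compound 1 to compound 3 (0.64 log units; beyond the scatter), so what sits at this position changes the read-out by more than the usual scatter. The phenyl ring is nevertheless not needed for a measurable result, as compound 3 still gives a number, 45700 nM. Compound 2 stands at a limit of the assay and not at a number: the limit of > 100000 nM in this assay, at which 1 of the 3 values shown sits.

With only phenyl and bromo compared at this position, the compounds shown leave open whether the step follows the number of heavy atoms in the group or the identity of the group. A methoxy group, an amine or a carboxylic acid at the same carbon would remain to be compared with compound 1 and compound 3.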